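Cytotoxicity notes: compound 4 against the measured set

The source may report more compounds than this note shows. Statements on the series, on what has been measured and on what is new or still open speak of the compounds shown alone.

All compounds share the core of compound 1 `Cc1cc(NC(=O)Nc2ccc(N)cc2)c2ccccc2n1` and differ only in the aryl group on the amide-type nitrogen. In an ADME assay on HepG2 cells (Homo sapiens) for cytotoxicity, with a stated time of 72 h (a higher number here means that more compound is needed for the effect, a lower number that less compound is needed), compound 1 gives > 25000 nM, which is a limit of the assay and not a number. Compound 2 `Cc1cc(NC(=O)Nc2ccc(C(N)=O)cc2)c2ccccc2n1` gives > 25000 nM, likewise a limit. Compound 3 `Cc1cc(NC(=O)Nc2ccc(SC(F)(F)F)cc2)c2ccccc2n1` gives 20000 nM. The step that the two limits leave unreadable from compound 1 to compound 2 cannot be read because the limit of > 25000 nM in this assay, at which 2 of the 3 values shown sit, holds both of its values. The steps of an at least 1.2-fold lower number from compound 1 to compound 3 (0.09 log units; that floor lies within the scatter) and an at least 1.2-fold lower number from compound 2 to compound 3 (0.09 log units; that floor lies within the scatter) are both floors that sit within the scatter, so no group tested so far moves the read-out beyond it.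

Compound 4 `Cc1cc(NC(=O)Nc2cccc(F)c2)c2ccccc2n1` is not yet measured; it differs from compound 1 by 3-fluorophenyl in place of 4-aminophenyl on an amide-type nitrogen. For the measured compounds named here, the only measured step that bears on it, replacing the amino group of compound 1 by another group, is an at least 1.2-fold lower number from compound 1 to compound 3 (0.09 log units; that floor lies within the scatter), within the scatter. No step beyond the scatter is therefore expected in this assay, in either direction. Compound 4 is expected to give about 25000 nM, in the range 10000 nM to 60000 nM. The expected step of a number no higher from compound 1 to compound 4 (the limit leaves the size open) is an estimate that stays within the scatter, most likely again reported as a limit.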

Compound 4, half-maximal effective concentration: > 25000 nM
Compound 4 ended at the assay's limit; the forecaster's own chance of this, stated with the estimate: 60%; the middle value sits exactly at the limit.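

In this assay compound 4 gives > 25000 nM, a limit of the assay and not a number. The step from compound 1 to compound 4 cannot be read, because both sit at the same limit: the limit of > 25000 nM in this assay, at which 3 of the 4 values shown sit.

The compounds shown leave open whether any aryl group on the shared core moves the read-out beyond the scatter.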